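The source may hold more compounds than are shown below. What is called first, only, known or untested is meant among the compounds shown, and "the series" means these compounds.

Working notes on the curcumin-type series in a functional assay on MDA-MB-231 cells (Homo sapiens) for antiproliferative activity, read by MTT assay, with a stated time of 72 h; a lower number here means a stronger inhibitor, a higher number a weaker inhibitor.

Compound 1 `COc1cc(/C=C/C(=O)/C=C(O)/C=C/c2ccc(OC(=O)C(C)(CO)CO)c(OC)c2)ccc1OC(=O)C(C)(CO)CO` gives 2670 nM in this assay. Compound 2 `COc1cc(/C=C/C(O)=C/C(=O)/C=C/c2ccc(OC(=O)C(C)(CO)CO)c(OC)c2)ccc1O` carries the same change that is to be studied here, (hydrogen in place of (1,1-bis(hydroxymethyl)ethyl)carbonyl on an oxygen on an aromatic ring), and in this assay compound 2 gives 5940 nM; the step is a 2.2-fold higher number from compound 1 to compound 2 (0.35 log units; beyond the scatter).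

Compound 3 `COc1ccc(/C=C/C(=O)/C=C(O)/C=C/c2ccc(OC)c(OC(=O)C(C)(CO)CO)c2)cc1OC(=O)C(C)(CO)CO` holds the same atoms as compound 1 joined differently; the difference between the two cores is not broken down here. In this assay compound 3 gives 4610 nM, which sits near compound 2 and compound 1 within the usual scatter.

Compound 4 `COc1ccc(/C=C/C(O)=C/C(=O)/C=C/c2ccc(OC)c(OC(=O)C(C)(CO)CO)c2)cc1O` is the unmeasured member, made from compound 3 by hydrogen in place of (1,1-bis(hydroxymethyl)ethyl)carbonyl on an oxygen on an aromatic ring. The place line is the same word for word as for the change from compound 1 to compound 2, so this is the same change on a different core. Among the measured compounds shown here, the only precedent is the single step from compound 1 to compound 2, so the expectation rests on that step alone and on compound 3 giving 4610 nM. Compound 4 is expected to show a step of about a 2.1-fold higher number from compound 3 to compound 4 (0.33 log units; beyond the scatter), a modest weakening. The estimate for compound 4 is 9800 nM, with a range from 4600 nM to 21000 nM.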

Compound 4, half-maximal inhibitory concentration: 2290 nM
For compound 4 the middle estimate is 4.3-fold (0.63 log units) above the measured one, outside the stated range (below it).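

In this assay, putting hydrogen in place of (1,1-bis(hydroxymethyl)ethyl)carbonyl on an oxygen on an aromatic ring gives a 2.0-fold lower number from compound 3 to compound 4 (0.30 log units; within the scatter), so the weakening seen with this change on the other core does not recur here. The same change therefore does not carry over as a fixed step between these two cores, and the two steps differ by more than their scatter: the same change on two cores in this assay, a 2.2-fold higher number (0.35 log units; beyond the scatter) from compound 1 to compound 2 and a 2.0-fold lower number (0.30 log units; within the scatter) from compound 3 to compound 4, 4.5-fold (0.65 log units) apart, beyond the scatter of two such steps

This rests on a single pair per core; it shows that the earlier step cannot be transferred directly in this series, but it does not explain the difference, and the new step, being within the scatter, does not establish a gain in its own right.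

The compounds shown leave open whether the same core dependence appears with other groups on that oxygen, such as an acetyl ester or a methyl ether. Also open, from the compounds shown here alone, is what happens on each core when the remaining (1,1-bis(hydroxymethyl)ethyl)carbonyl is replaced by hydrogen as well.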